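The compounds below may be only part of what the source reports. "The series", "measured", "known", "first", "only" and "open" are said of these compounds alone.

Series notes. Compound 1 `O=C(NNC(=O)c1cc([N+](=O)[O-])c[nH]1)Nc1ccc([N+](=O)[O-])cc1` and compound 2 `O=C(NNC(=O)c1cc([N+](=O)[O-])c[nH]1)Nc1ccc(Cl)cc1` share a core; compound 3 `O=C(NNC(=S)Nc1ccc([N+](=O)[O-])cc1)c1cc([N+](=O)[O-])c[nH]1` and compound 4 `O=C(NNC(=S)Nc1ccc(Cl)cc1)c1cc([N+](=O)[O-])c[nH]1` share a second core, and the difference between the two cores is not broken down here. In an ADME assay on Vero cells (Chlorocebus sabaeus) for cytotoxicity, read by MTT assay, with a stated time of 72 h (on this read-out higher numbers stand for weaker inhibition and lower numbers for stronger inhibition), compound 1 gives 211000 nM and compound 2 gives 218000 nM, so the change chloro in place of nitro on an aromatic carbon made a 1.0-fold higher number from compound 1 to compound 2 (0.01 log units; within the scatter). In this assay compound 3 gives 529000 nM, a higher number than either compound 1 or compound 2 by a margin beyond the scatter. Compound 4 carries the same kind of change on the second core, (chloro in place of nitro on an aromatic carbon), with the two place descriptions matching word for word. Compound 4 is expected to sit close to compound 3 in this assay, the expected step being a 1.0-fold lower number from compound 3 to compound 4 (0.01 log units; within the scatter), because a 1.0-fold higher number from compound 1 to compound 2 (0.01 log units; within the scatter) was within the scatter. On that basis compound 4 is estimated at 520000 nM, with a range from 290000 nM to 950000 nM.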

Compound 4, half-maximal inhibitory concentration: 191000 nM
Beside the measured number, compound 4's estimate is 2.7-fold (0.43 log units) above it; measured number outside the range, below it.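

In this assay the change from nitro to chloro does not carry over unchanged from one core to the other: the same change on two cores in this assay, a 1.0-fold higher number (0.01 log units; within the scatter) from compound 1 to compound 2 and a 2.8-fold lower number (0.44 log units; beyond the scatter) from compound 3 to compound 4, 2.9-fold (0.46 log units) apart, beyond the scatter of two such steps. Going by these compounds alone, on the second core the change gives a 2.8-fold lower number from compound 3 to compound 4 (0.44 log units; beyond the scatter), so a step within the scatter on the first core is no guide to the second. This rests on a single pair on each core and shows neither a rule for other cores nor why the two cores differ.

The compounds shown carry only nitro or chloro at this place, so it remains open how an amine, a carboxylic acid or a methoxy group would behave on either core. From the compounds shown here alone, whether the gap between the two steps would recur in any other read-out also remains open.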